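The source may report more compounds than this note shows. Statements on the series, on what has been measured and on what is new or still open speak of the compounds shown alone.

Among the compounds with values here, in a functional assay on CCRF-CEM cells (Homo sapiens) for inhibition, with a stated time of 72 h (on this read-out lower numbers stand for stronger inhibition and higher numbers for weaker inhibition), compound 1 `COC(=O)C[C@H](NC(=O)OC(C)(C)C)C(=O)N(Cc1ccccc1)C1(C(=O)NCc2ccccc2)CCN(Cc2ccccc2)CC1` gives 19000 nM, the lower of the two numbers measured so far. Within the data shown here, the only other measured compound, compound 2 `C=CCOC(=O)N1CCC(C(=O)NCc2ccccc2)(N(Cc2ccccc2)C(=O)[C@H](CC(=O)OC)NC(=O)OC(C)(C)C)CC1`, gives 65000 nM. Here allyloxycarbonyl stands in place of benzyl on an amine nitrogen in a ring, and the result is a 3.4-fold higher number from compound 1 to compound 2 (0.53 log units; beyond the scatter), a modest step toward weaker inhibition.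

Compound 3 `COC(=O)C[C@H](NC(=O)OC(C)(C)C)C(=O)N(C1CC1)C1(C(=O)NCc2ccccc2)CCN(Cc2ccccc2)CC1` keeps that ring nitrogen as it is in compound 1 and changes another place, with cyclopropyl in place of benzyl on an amide-type nitrogen. Among the measured compounds shown here, no measured step touches this nitrogen, so the evidence is indirect and thin. For the measured compounds named here, the one guide is that replacing a different benzyl gave a 3.4-fold higher number from compound 1 to compound 2 (0.53 log units; beyond the scatter). A single step cannot settle the direction, but a rise of similar modest size in this assay is the most reasonable expectation, which would mean somewhat weaker inhibition. The expected change is a 2.0-fold higher number from compound 1 to compound 3 (0.30 log units; within the scatter). The estimate for compound 3 is 38000 nM, with an expected range of 14000 nM to 100000 nM.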

Compound 3, half-maximal inhibitory concentration: 6700 nM
Estimate against measurement, compound 3: 5.7-fold (0.75 log units) above; the measured number lies below the stated range.
By their numbers in this assay, from the lowest: compound 3; then compound 1; then compound 2.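

On the amide-type nitrogen in this assay, the change from benzyl to cyclopropyl gives a 2.8-fold lower number from compound 1 to compound 3 (0.45 log units; beyond the scatter), so this position tolerates losing the six-membered aromatic ring and inhibition even grows stronger, by a step beyond the scatter. This step runs the opposite way from the other benzyl replacement, on the ring nitrogen, which gives a 3.4-fold higher number from compound 1 to compound 2 (0.53 log units; beyond the scatter), so in these three compounds the effect of replacing a benzyl depends on which nitrogen carries it. Nothing in the available data explains the gain at the amide-type nitrogen.

Cyclopropyl differs from benzyl both in its smaller count of heavy atoms and in having a non-aromatic ring, and this single pair cannot show which of the two differences goes with the lower number. A cyclohexyl group on the same nitrogen would keep a larger carbon ring without aromaticity, and an isopropyl group would offer a small open chain, so either could help to separate ring size, ring type and the presence of a ring at all.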